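The source may hold more compounds than are shown below. What is called first, only, known or untested is meant among the compounds shown, and "the series" means these compounds.

Compound 3 `C[C@@H](NC(=O)Nc1cccc(C(F)(F)F)c1)c1ccccc1` is one of three compounds built on a shared core. In an ADME assay on the whole organism with Oryza sativa as the target, tested at 0.1 uM (a lower number here means a stronger effect, a higher number a weaker effect of the compound at the concentration tested), compound 3 gives 82%, the second highest of the three numbers. Compound 2 `CC(C)c1cccc(NC(=O)N[C@H](C)c2ccccc2)c1` gives 74%, a value within the scatter of that of compound 3. Compound 1 `CCc1cccc(NC(=O)N[C@H](C)c2ccccc2)c1` gives 97%, which lies above compound 3 beyond the scatter. Compound 4 `COc1cccc(NC(=O)N[C@H](C)c2ccccc2)c1` has not yet been measured and differs from compound 3 in one place: methoxy in place of trifluoromethyl on an aromatic carbon. Two measured steps alter the same group: a number 15 percentage points lower from compound 1 to compound 3 (beyond the scatter), and a number 8 percentage points higher from compound 2 to compound 3 (within the scatter). Within the data shown here, neither involves methoxy; they show only that exchanging this group moves the number modestly or not at all. For compound 4 the expected value is 85%, within 70% to 98%. The estimated step is a number 3 percentage points higher from compound 3 to compound 4 (within the scatter).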

Compound 4, a percentage reported as activity, at one concentration (the size of the read-out at that concentration, not a potency): 104%
Compound 4: middle estimate off by 19 percentage points, on the low side; measured number above the stated range.
By their numbers in this assay, from the lowest: compounds 2 and 3 (each within the scatter of the next); then compounds 1 and 4 (each within the scatter of the next).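

In this assay, methoxy on this aromatic carbon gives a number 22 percentage points higher from compound 3 to compound 4 (beyond the scatter) and a number 30 percentage points higher from compound 2 to compound 4 (beyond the scatter) and thus a weaker effect at the concentration tested. Set against ethyl, the same exchange gives a number 7 percentage points higher from compound 1 to compound 4 (within the scatter) and the four groups thus fall into two pairs: methoxy with ethyl at the weaker end, trifluoromethyl with isopropyl at the stronger end. No measurement at hand explains this split. On these data alone, it stays open which pair an amine, a hydroxyl group or a longer chain on this carbon would join.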